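This account rests on a few compounds, and the source may have more. Where it says the series, first, only, none or still open, it means among the compounds named here.

In a functional assay on DU-145 cells (Homo sapiens) for inhibition, read by trypan blue exclusion, with a stated time of 96 h (a higher number here means a weaker inhibitor of growth, a lower number a stronger inhibitor of growth), compound 1 (`O=C(/C(=C\c1ccc(O)c([N+](=O)[O-])c1)SCc1ccccc1Cl)c1ccc(Cl)cc1`) gives 10000 nM and compound 2 (`O=C(/C(=C\c1ccc(Cl)cc1)SCc1ccccc1Cl)c1ccc(Cl)cc1`) gives 12000 nM, with a 1.2-fold higher number from compound 1 to compound 2 (0.08 log units; within the scatter). Compound 3 (`CN(C)c1ccc(/C=C(/SCc2ccccc2Cl)C(=O)c2ccc(Cl)cc2)cc1`) reads > 100000 nM, which is a limit of the assay and not a number. The next structure, compound 4 (`CN(C)c1ccc(/C=C(\C(=O)c2ccc(Cl)cc2)S(=O)(=O)c2ccc(Br)cc2)cc1`), keeps the 4-(dimethylamino)phenyl group, and the change is (4-bromophenyl)sulfonyl in place of (2-chlorobenzyl)sulfanyl on a double-bonded chain carbon bound to a carbonyl carbon and a double-bonded chain carbon, on a double-bonded chain carbon bound to a carbonyl carbon and a double-bonded chain carbon. The measured steps, an at least 10-fold higher number from compound 1 to compound 3 (1.00 log units; beyond the scatter) and an at least 8.3-fold higher number from compound 2 to compound 3 (0.92 log units; beyond the scatter), both alter that 4-substituted phenyl group, so none of them measures this exchange directly. With the dimethylamino group retained, only a modest move towards a lower number is expected, namely an at least 2.0-fold lower number from compound 3 to compound 4 (0.30 log units; that floor lies within the scatter). Compound 4 is estimated at 50000 nM, with an expected range from 8000 nM to 150000 nM.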

Compound 4, concentration for 50% growth inhibition: > 100000 nM
Compound 4: only a limit was reported (the forecaster's own chance of this, stated with the estimate: 40%); middle value at least 2.0-fold (0.30 log units) from the limit.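

Compound 3 and compound 4 both stop at a limit of the assay, so no step between them can be read: the limit of > 100000 nM in this assay, at which 2 of the 4 values shown sit.

The compounds shown leave open whether (4-bromophenyl)sulfonyl in place of (2-chlorobenzyl)sulfanyl changes growth inhibition at all while the 4-(dimethylamino)phenyl group stays.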